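Moving the Amine Into the Ring: Compound 2 to Compound 4

This account rests on a few compounds, and the source may have more. Where it says the series, first, only, none or still open, it means among the compounds named here.

Compound 1 `N[C@H](C(=O)Nc1cc2cc[nH]c(=O)c2cc1Cl)C1CCCCC1` and compound 2 `N[C@H]1CC[C@@H](C(=O)Nc2cc3cc[nH]c(=O)c3cc2Cl)CC1` share one core and differ only in the group on the carbonyl carbon. In a functional assay (aorta) with Rattus norvegicus as the target (a higher number here means that more compound is needed for the effect, a lower number that less compound is needed), compound 1 gives 180 nM, and in this assay compound 2 gives 180 nM; the two stand level within the scatter, so neither counts as the stronger. Compound 3 `CN(C)[C@H]1CC[C@@H](C(=O)Nc2cc3cc[nH]c(=O)c3cc2Cl)CC1` is a close relative, and in this assay compound 3 gives "not determined" (no result reported), so no number is available for it. Compound 4 `CN1CCC(C(=O)Nc2cc3cc[nH]c(=O)c3cc2Cl)CC1` follows from compound 2 by one change: 1-methylpiperidin-4-yl in place of 4-aminocyclohexyl on a carbonyl carbon. For the measured compounds named here, no measured step of this kind exists here, so the expected step in this assay is a small loss, possibly none beyond the scatter. Compound 4 is estimated at 300 nM, with a range from 80 nM to 1200 nM. The expected step is a 1.7-fold higher number from compound 2 to compound 4 (0.22 log units; within the scatter).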

Compound 4, half-maximal effective concentration: 250 nM
Compound 4: middle estimate off by 1.2-fold (0.08 log units), on the high side; low and high end bracket the measured number.
By their numbers in this assay, from the lowest: compounds 1, 2 and 4 (each within the scatter of the next).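

Putting 1-methylpiperidin-4-yl in place of 4-aminocyclohexyl on a carbonyl carbon gives in this assay only a 1.4-fold higher number from compound 2 to compound 4 (0.14 log units; within the scatter) and stays within the scatter. The earlier numbers covered only rings of carbon, whereas this place also accepts a ring with a hetero atom and a group with no hydrogen-bond donor, with no real change in the read-out. No measurement shown here bears on the cause of this result. Still open, going by these compounds, is how this assay would respond to a piperidin-4-yl group without the methyl, or to a carboxylic acid in place of the amine.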